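The source may hold more compounds than are shown below. What is called first, only, known or untested is meant among the compounds shown, and "the series" means these compounds.

The measured compounds:
compound 1 `Cc1ccc2nc(NC(=O)c3cn(-c4ccccc4)nc3-c3ccccc3)sc2c1`, in a functional assay on U-87MG ATCC cells for cytotoxicity against U-87 MG (Homo sapiens), read by MTT assay, with a stated time of 72 h (a lower number here means a stronger inhibitor, a higher number a weaker inhibitor), compound 1 gives 23200 nM
compound 2 `O=C(Nc1nc2ccc(F)cc2s1)c1cn(-c2ccccc2)nc1-c1ccc(F)cc1`, compound 2 gives 12500 nM
compound 3 `COc1ccc2nc(NC(=O)c3cn(-c4ccccc4)nc3-c3ccc(F)cc3)sc2c1`, compound 3 gives only a limit, > 50000 nM

Three amides share one core and differ in two places. Going by the values given here, compound 3 stands at the limit of this assay, not at a number, and the one value the limit of > 50000 nM in this assay, at which 1 of the 3 values shown sits, belongs to it. Of the two numbers that are known, compound 2 is the lower and compound 1 the higher. Among the compounds with values here, the one measured step that touches compound 3 is an at least 4.0-fold higher number from compound 2 to compound 3 (0.60 log units; beyond the scatter), so the methoxy compound is the weakest of the three.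

Compound 4 `Cc1ccc2nc(NC(=O)c3cn(-c4ccccc4)nc3-c3ccc(F)cc3)sc2c1` arises from compound 3 by methyl in place of methoxy on an aromatic carbon. Within the data shown here, no measured step covers this exact exchange. Compound 1 carries the same methyl but a plain phenyl ring, and compound 2 shows that a fluoro group at the position in question sits far below the limit. He therefore expects a drop in this assay, estimated as an at least 2.0-fold lower number from compound 3 to compound 4 (0.30 log units; that floor lies within the scatter), back into the range where compound 1 and compound 2 lie. His estimate for compound 4 is 25000 nM, within 10000 nM and 60000 nM, with some chance that only a limit is returned.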

Compound 4, half-maximal inhibitory concentration: > 50000 nM
Compound 4: a limit, no number; the forecaster's own chance of this, stated with the estimate: 25%; middle value at least 2.0-fold (0.30 log units) from the limit.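

In this assay, the loss seen with methoxy turns out not to be confined to methoxy: exchanging fluoro for methyl on this aromatic carbon gives an at least 4.0-fold higher number from compound 2 to compound 4 (0.60 log units; beyond the scatter), so among the three compounds with the fluorinated phenyl ring, only the fluoro compound returns a number. Methyl on this carbon does not decide the outcome alone, as the other single change, fluoro in place of hydrogen on an aromatic carbon with the methyl kept, gives an at least 2.1-fold higher number from compound 1 to compound 4 (0.33 log units; beyond the scatter). Compound 3 and compound 4 both stand at a limit, so the step between methoxy and methyl cannot be read: the limit of > 50000 nM in this assay, at which 2 of the 4 values shown sit.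

The compounds shown leave open how methoxy and methyl rank against each other, and whether the fluoro group would give a lower or a higher number with the plain phenyl ring of compound 1 in place of the fluorinated one. They also leave open whether a chloro group, a hydroxyl group or an amine on this aromatic carbon would return a number or stand at the limit.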